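Pyrimidin-5-yl in place of 2-cyanoethyl on the carbonyl

The source may report more compounds than this note shows. Statements on the series, on what has been measured and on what is new or still open speak of the compounds shown alone.

Of the compounds shown here, three have been read so far in a physicochemical assay for solubility, measured as kinetic solubility, with a stated time of 1 h, at pH 7.4 (on this read-out higher numbers stand for higher solubility and lower numbers for lower solubility), and compound 1 (`O=C(Nc1nc(-c2ccc(Cl)c(Cl)c2)cs1)c1c(F)cccc1F`) gives 5000 nM there. Compound 2 (`NC1=NN(c2ccc(Cl)c(Cl)c2)CC1`) gives 69000 nM there, and compound 3 (`N#CCCC(=O)NC1=NN(c2ccc(Cl)c(Cl)c2)CC1`) gives 39000 nM there. That places compound 3 within the scatter of compound 2 and clearly above compound 1.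

Compound 4 (`O=C(NC1=NN(c2ccc(Cl)c(Cl)c2)CC1)c1cncnc1`) has not been measured yet. Its difference from compound 3 is pyrimidin-5-yl in place of 2-cyanoethyl on a carbonyl carbon and nothing else changes, so pyrimidin-5-yl stands in place of 2-cyanoethyl on a carbonyl carbon.

Among the measured compounds shown here, the only measured step that bears on this is a 1.8-fold lower number from compound 2 to compound 3 (0.25 log units; within the scatter) with (2-cyanoethyl)carbonyl in place of hydrogen on an amine nitrogen, and it stayed within the scatter. For the measured compounds named here, no measured compound carries pyrimidin-5-yl, so the exchange itself is untested. Going by the values given here, compound 1 also has a ring on its carbonyl carbon and gives 5000 nM on another core, but no measured step links it to compound 3, so it only widens the range downward.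

The step expected is a 1.6-fold lower number from compound 3 to compound 4 (0.19 log units; within the scatter) and so no change beyond the scatter is anticipated. In this assay compound 4 is estimated at 25000 nM with an expected range from 8000 nM to 60000 nM as its likely span.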

Compound 4, solubility: 8000 nM
Beside the measured number, compound 4's estimate is 3.1-fold (0.49 log units) above it, and the stated range covers the measured number.
By their numbers in this assay, from the lowest: compounds 1 and 4 (each within the scatter of the next); then compounds 3 and 2 (each within the scatter of the next).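

Among the compounds shown here, with the read-out taken from this assay, pyrimidin-5-yl in place of 2-cyanoethyl on a carbonyl carbon gives a 4.9-fold lower number from compound 3 to compound 4 (0.69 log units; beyond the scatter), and this is the first step on the shared core to lie beyond the scatter. For the compounds shown here, the only earlier step on that core, a 1.8-fold lower number from compound 2 to compound 3 (0.25 log units; within the scatter), stayed within the scatter when (2-cyanoethyl)carbonyl replaced hydrogen on an amine nitrogen, so the number now turns out to depend on what the carbonyl carbon carries, and not only on whether the amine nitrogen carries a hydrogen or a (2-cyanoethyl)carbonyl. No measurement at hand accounts for the size of this step.

The exchange removes a chain with no ring and a triple bond and brings in a six-membered aromatic ring with 2 hetero atoms, so these compounds leave open whether the step follows the loss of the nitrile or the arrival of the ring. A plain phenyl ring, a pyridine ring, or a longer chain ending in an amine or a carboxylic acid on the same carbonyl carbon would be needed to tell these apart.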